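Furan-2-yl to 3-chlorophenyl: what to expect next

This account rests on a few compounds, and the source may have more. Where it says the series, first, only, none or still open, it means among the compounds named here.

Compound 1, `Clc1ccc(-c2cc(-c3ccsc3)nc(-c3ccco3)c2)o1`, gives 8.2% in an assay on isolated protein for inhibition of DNA topoisomerase 1 (Homo sapiens), tested at 100 uM; on this read-out lower numbers stand for a weaker effect and higher numbers for a stronger effect at the one concentration tested.
Compound 2, `Clc1ccc(-c2cc(-c3ccco3)nc(-c3cccs3)c2)o1`, gives 16% in this assay.

Among these two numbers compound 2 stands highest, but its only neighbour, compound 1, is close: the step of a number 7.8 percentage points higher from compound 1 to compound 2 (within the scatter) is within the scatter, so the two compounds cannot be told apart on this read-out. The step from compound 1 to compound 2 exchanges thiophen-2-yl for thiophen-3-yl, which made no difference beyond the scatter.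

Compound 3, `Clc1cccc(-c2cc(-c3ccc(Cl)o3)cc(-c3cccs3)n2)c1`, differs from compound 2 in one place: 3-chlorophenyl in place of furan-2-yl on an aromatic carbon. The exchanged group sits next to the ring nitrogen of the shared core. No measured step involves furan-2-yl or 3-chlorophenyl, so nothing shown here bears directly on this change; the one step that is known, a number 7.8 percentage points higher from compound 1 to compound 2 (within the scatter), concerns a different group and was small. With no guidance pointing either way, the expected step of a number 1 percentage points lower from compound 2 to compound 3 (within the scatter) is none beyond the scatter. Compound 3 is therefore estimated at 15% in this assay, with a range from 0% to 40%.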

Compound 3, a percentage reported as inhibition, at one concentration (the size of the read-out at that concentration, not a potency): 42%
For compound 3 the middle estimate is 27 percentage points below the measured one, outside the stated range (above it).
By their numbers in this assay, from the lowest: compounds 1 and 2 (each within the scatter of the next); then compound 3.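

Exchanging furan-2-yl for 3-chlorophenyl next to the ring nitrogen gives, in this assay, a number 26 percentage points higher from compound 2 to compound 3 (beyond the scatter), the only step among these compounds that clears the scatter. The earlier step, a number 7.8 percentage points higher from compound 1 to compound 2 (within the scatter), stayed within the scatter and so could not show that any change on the shared core alters this read-out, whereas this one shows that the group at this position can. The change replaces a five-membered aromatic ring with 1 hetero atom by a six-membered aromatic ring of carbon only that also carries a chlorine, and no measurement shown here explains why the number rises.

Within the data shown here, the single step leaves open whether the gain belongs to the six-membered ring or to its chlorine, a question that a plain phenyl group at this position would help to settle. Also open, on these data alone, is how this position would respond to a group of a different kind, such as a phenyl ring carrying an aminomethyl group or a carboxylic acid, and whether the higher number at the one concentration tested would hold up as a true measure of potency.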